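Second methoxy on the compound 3 aryl group

This account rests on a few compounds, and the source may have more. Where it says the series, first, only, none or still open, it means among the compounds named here.

In a functional assay on HCT-116 cells (Homo sapiens) for antiproliferative activity, read by MTT assay, with a stated time of 72 h (on this read-out higher numbers stand for weaker inhibition and lower numbers for stronger inhibition), compound 1 `O=C(CCc1cccc2c1B(O)OC2)Nc1ccc(I)cc1` gives 50000 nM and compound 2 `COc1cc(OC)cc(-c2cccc(NC(=O)CCc3cccc4c3B(O)OC4)c2)c1` gives 53 nM while compound 3 `COc1cccc(-c2cccc(NC(=O)CCc3ccc4c(c3)B(O)OC4)c2)c1` gives 21000 nM as the second highest of the three numbers. Compound 3 sits just under compound 1 and far above compound 2. Compound 4 `COc1cc(OC)cc(-c2cccc(NC(=O)CCc3ccc4c(c3)B(O)OC4)c2)c1` turns 3-methoxyphenyl into 3,5-dimethoxyphenyl (methoxy in place of hydrogen on an aromatic carbon) with methoxy in place of hydrogen on an aromatic carbon. Among the compounds with values here, no measured pair isolates this change. Compound 2 carries 3,5-dimethoxyphenyl on a differently connected core and its 53 nM is only a loose guide. The expected 7.0-fold lower number from compound 3 to compound 4 (0.85 log units; beyond the scatter) is a fall beyond the scatter toward stronger inhibition. For compound 4 the estimated value is 3000 nM with an expected range from 200 nM to 30000 nM as the working figure.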

Compound 4, half-maximal inhibitory concentration: 3700 nM
For compound 4 the middle estimate is 1.2-fold (0.09 log units) below the measured one; the measured number falls inside the stated range.
By their numbers in this assay, from the lowest: compound 2; then compound 4; then compound 3; then compound 1.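

In this assay the second methoxy gives a 5.7-fold lower number from compound 3 to compound 4 (0.75 log units; beyond the scatter) as the first measured pair isolating this change on an aromatic carbon. With 3,5-dimethoxyphenyl held constant, the difference in the core group gives the larger 70-fold higher number from compound 2 to compound 4 (1.84 log units; beyond the scatter) and so the aryl change alone does not bring compound 4 level with compound 2. No evidence here bears on the reason for either step. On these data alone, whether an amine or a carboxylic acid on the same aromatic carbon would match methoxy remains open. So does the size of the methoxy step on the core of compound 2.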